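A few compounds are considered here, and "the series" means these few. Any claim that something is new, unique, unknown or untested is made for them only; others in the source may bear on it.

Measured so far:
- compound 1, `CC(Cn1ncccc1=O)C(=N)S`: 40.3%
- compound 2, `N=C(S)CCn1nc(-c2ccccc2)ccc1=O`: 53.7%

Both compounds were tested in a functional assay on the whole organism (stomach) for inhibition, with Rattus norvegicus as the target, at a dose of 100 mg/kg by the intraduodenal route; a higher number here means more inhibition at the dose given (going by the name of the read-out), a lower number less inhibition. Of the two numbers, compound 2 stands highest, and the nearest, compound 1, lies a gap below it that is beyond the usual scatter of such measurements. Within the data shown here, compound 1 and compound 2 differ from each other in more than one place, so their two values show only that compound 2 gives the larger inhibition, not which part of the structure carries that difference.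

The step under study goes from compound 2 to compound 3, `CC(Cn1nc(-c2ccccc2)ccc1=O)C(=N)S`, which has not yet been measured. The change is methyl in place of hydrogen on a saturated chain carbon bound to a carbon with a double bond to nitrogen and a saturated chain carbon.

Among the measured compounds shown here, no measured pair differs by this change alone, so nothing in the data shows how the methyl by itself shifts the read-out. With compound 2 at 53.7% as the only anchor, the expected step from compound 2 to compound 3 is a number 3.7 percentage points lower from compound 2 to compound 3 (within the scatter), that is, none beyond the scatter. Compound 3 is therefore estimated at 50% in this assay, with a range from 30% to 70%.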

Compound 3, a percentage reported as inhibition, in the whole organism at one dose (the size of the read-out at that dose, not a potency): 86.4%
Compound 3: the middle estimate sits 36.4 percentage points below what was measured, outside the stated range (above it).
By their numbers in this assay, from the lowest: compound 1; then compound 2; then compound 3.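

In this assay, methyl in place of hydrogen on a saturated chain carbon bound to a carbon with a double bond to nitrogen and a saturated chain carbon gives a large change, a move of a number 32.7 percentage points higher from compound 2 to compound 3 (beyond the scatter), so this position responds strongly to a single added carbon when the phenyl is present. The two earlier compounds differed in more than one place, but compound 3 now gives a clean reading for the phenyl as well: phenyl in place of hydrogen on an aromatic carbon, with the methyl kept, gives a move of a number 46.1 percentage points higher from compound 1 to compound 3 (beyond the scatter), so each of the two groups adds to the inhibition seen once the other is in place. Nothing available explains why either change has this effect at this dose.

Whether the methyl would give a gain of this size without the phenyl remains open, since the compounds shown include no pair that tests it. From the compounds shown here alone, it is also open whether an ethyl group or a longer chain on the same carbon would raise the inhibition further or lower it.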